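The source may report more compounds than this note shows. Statements on the series, on what has been measured and on what is new or still open speak of the compounds shown alone.

Three compounds share one core and were tested in a functional assay on A549 cells (Homo sapiens) for cytotoxicity, read by MTT assay, with a stated time of 48 h; a higher number here means a weaker inhibitor, a lower number a stronger inhibitor. Compound 2 `CCn1c(/C=C2/C(=O)Nc3ccccc32)nc2ccccc21` gives only a limit of the assay, > 50000 nM, in this assay. Compound 1 `CCn1c(/C=C2/C(=O)Nc3ccc(F)cc32)nc2ccccc21` likewise gives only a limit, > 50000 nM. For the measured compounds named here, compound 3 `CC(C)n1c(/C=C2/C(=O)Nc3ccccc32)nc2ccccc21` gives 35300 nM, the single value here that is a number. Compound 3 differs from compound 2 by methyl in place of hydrogen on a saturated chain carbon bound to an aromatic nitrogen and a saturated chain carbon, and an at least 1.4-fold lower number from compound 2 to compound 3 (0.15 log units; that floor lies within the scatter). Compound 1 differs from compound 2 by fluoro in place of hydrogen on an aromatic carbon, a change whose step, a step that the two limits leave unreadable from compound 2 to compound 1, cannot be read because the limit of > 50000 nM in this assay, at which 2 of the 3 values shown sit, covers both of its ends. Compound 4 `CC(C)n1c(/C=C2/C(=O)Nc3ccc(F)cc32)nc2ccccc21`, not yet measured, carries the same change on the core of compound 3: fluoro in place of hydrogen on an aromatic carbon. The place of the new fluoro is described in the same words for both pairs, so this is the same change, made here on the core that carries the extra methyl. The earlier step that the two limits leave unreadable from compound 2 to compound 1 shows no readable size, so the expected step of a 1.1-fold higher number from compound 3 to compound 4 (0.05 log units; within the scatter) is taken as close to no change, resting on compound 3 at 35300 nM. Compound 4 is thus expected to give about 40000 nM, somewhere from 15000 nM to 100000 nM, with a fair chance that it too is reported only as a limit.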

Compound 4, half-maximal inhibitory concentration: 28500 nM
Beside the measured number, compound 4's estimate is 1.4-fold (0.15 log units) above it, within the range that was stated.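

In this assay, fluoro in place of hydrogen on an aromatic carbon gives a 1.2-fold lower number from compound 3 to compound 4 (0.09 log units; within the scatter), so on the core of compound 3 this change has no effect that can be told apart from the scatter. The same fluoro change from compound 2 to compound 1 cannot be read, so nothing shows whether it carries over from one core to the other, because both of its ends sit at a limit of the assay: the limit of > 50000 nM in this assay, at which 2 of the 4 values shown sit. The methyl change can be followed on two cores, and on the fluoro-bearing core it gives an at least 1.7-fold lower number from compound 1 to compound 4 (0.24 log units; that floor lies within the scatter), but this does not show that it has the same size on both: the same change on two cores in this assay, an at least 1.4-fold lower number (0.15 log units; that floor lies within the scatter) from compound 2 to compound 3 and an at least 1.7-fold lower number (0.24 log units; that floor lies within the scatter) from compound 1 to compound 4; the limit leaves it open whether they differ.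

The compounds shown leave open how far the numbers of compound 1 and compound 2 really lie from those of compound 3 and compound 4. They also leave open what a chloro or a nitrile on that aromatic carbon, or a longer chain or an amine on the aromatic nitrogen, would do.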